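This account rests on a few compounds, and the source may have more. Where it says the series, first, only, none or still open, it means among the compounds named here.

Working notes on the series.

Compound 1 `CCOC(=O)c1nn(-c2ccccc2)c(-c2ccc(OC)cc2OC)c1-c1ccccc1` in a functional assay on the whole organism (strain albino) for inhibition, with Rattus norvegicus as the target, read by paw edema, with stated times of 30 min and 1 h, at a dose of 25 mg/kg by the intraperitoneal route (a lower number here means less inhibition, a higher number more inhibition at the dose given (going by the name of the read-out)), gives 17.7%. Compound 2 `COc1ccc(C2=NN(C(=O)NS(=O)(=O)c3ccc(C)cc3)CC2C)c(OC)c1`, built on a different scaffold, in this assay gives 23.7%. Compound 3 `CCOC(=O)c1nn(-c2ccc(Cl)cc2)c(-c2ccc(OC)cc2OC)c1-c1ccccc1` in this assay gives 6.89%, the lowest of the three numbers; the gap to compound 1 and the gap to compound 2 both lie beyond the scatter. Within the data shown here, the only single-point step measured so far is a number 10.8 percentage points lower from compound 1 to compound 3 (beyond the scatter), and it concerns the aryl ring on the nitrogen, not the ester.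

Compound 4 `COc1ccc(-c2c(-c3ccccc3)c(C(=O)O)nn2-c2ccc(Cl)cc2)c(OC)c1` differs from compound 3 in one place: hydrogen in place of ethyl on an oxygen next to a carbonyl group. Among the measured compounds shown here, no measured pair varies the ester, so no step bears directly on this change, and nothing in the data says in which direction it should move. With compound 3 sitting at 6.89%, the working expectation is a change of about a number 3.1 percentage points higher from compound 3 to compound 4 (within the scatter), that is, nothing beyond the scatter. Compound 4 is therefore estimated at 10%, within a range of 0% to 25% that covers the uncertainty of an unprecedented change.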

Compound 4, a percentage reported as inhibition, in the whole organism at one dose (the size of the read-out at that dose, not a potency): 37%
Estimate against measurement, compound 4: 27 percentage points below; measured number above the stated range.
By their numbers in this assay, from the lowest: compound 3; then compounds 1 and 2 (each within the scatter of the next); then compound 4.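

The ester position now has a measured step: hydrogen in place of ethyl on an oxygen next to a carbonyl group gives a number 30.1 percentage points higher from compound 3 to compound 4 (beyond the scatter) in this assay. This ethoxycarbonyl to carboxy change runs opposite to the chloro step, a number 10.8 percentage points lower from compound 1 to compound 3 (beyond the scatter), and is the larger of the two, so this position can move the read-out at least as far as the aromatic carbon that carries chloro. Nothing shown accounts for the direction or size of this step.

From the compounds shown here alone, the carboxy group appears only in compound 4, which also carries chloro, so whether it gives a similar step with hydrogen in place of that chloro, as in compound 1, stays open. Going by these compounds, how an amide or a methyl ester would read at this position also stays open.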